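Compound 1 to compound 4: replacing the phenyl

A few compounds are considered here, and "the series" means these few. Any claim that something is new, unique, unknown or untested is made for them only; others in the source may bear on it.

compound 1 `Cc1nc(-c2ccccc2)c(C(=O)N2CCN(c3cccc(Cl)c3)CC2)o1` 2%
compound 2 `Cc1nc(-c2ccccc2)c(C(=O)N2CCN(c3cccc(C)c3C)CC2)o1` 83.6%
compound 3 `Cc1ccc(C)c(N2CCN(C(=O)c3oc(C)nc3-c3ccccc3)CC2)c1` 1.4%

All three values come from an ADME assay on microsomes from liver (Mus musculus) for metabolic stability, read by LC-MS, with a stated time of 1 h, tested at 5 uM (a lower number here means that less of the compound is left, a higher number that more of the compound is left), and compound 1 sits at the low end of them. Against the other low member the step is a number 0.6 percentage points lower from compound 1 to compound 3 (within the scatter) and against the high member it is a number 81.6 percentage points higher from compound 1 to compound 2 (beyond the scatter) in the same read-out.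

Compound 4 `COc1cc(-c2nc(C)oc2C(=O)N2CCN(c3cccc(Cl)c3)CC2)ccc1O` keeps the 3-chlorophenyl on the amine nitrogen and differs on an aromatic carbon of the five-membered aromatic ring: 4-hydroxy-3-methoxyphenyl in place of phenyl on an aromatic carbon is the whole change.

Among the measured compounds shown here, all the measured steps concern the group on the amine nitrogen, and none touches the phenyl. They show how far a single change can move this series: the step of a number 82.2 percentage points lower from compound 2 to compound 3 (beyond the scatter) separates two dimethylphenyl isomers. They bear on compound 4 only indirectly, since compound 4 lacks the 2,3-dimethylphenyl of compound 2 and shares the 3-chlorophenyl of compound 1. No measurement covers a change at the phenyl, so the expectation is weakly supported. No step beyond the scatter is expected, and the estimated step is a number 2 percentage points higher from compound 1 to compound 4 (within the scatter) in this assay on that basis.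

For compound 4 the estimate is 4% with an expected range from 0% to 15% in this read-out.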

Compound 4, percent of the compound remaining: 72.5%
The estimate for compound 4 lay 68.5 percentage points below the measured number; measured number outside the range, above it.
By their numbers in this assay, from the lowest: compounds 3 and 1 (each within the scatter of the next); then compound 4; then compound 2.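

In this assay, the aromatic carbon next to the ring nitrogen proves to be a second place where a single change moves the read-out strongly: with the 3-chlorophenyl on the amine nitrogen kept, 4-hydroxy-3-methoxyphenyl in place of phenyl gives a number 70.5 percentage points higher from compound 1 to compound 4 (beyond the scatter). The earlier steps shown here all concerned the group on the amine nitrogen, so they could not show that the 3-chlorophenyl is compatible with a high number once the phenyl is replaced. Nothing at hand bears on why this change has so large an effect, whether through the added hydroxy group, the added methoxy group or the two together.

The compounds shown do not separate the two substituents, so the step cannot be assigned to either one, and a 4-hydroxyphenyl or a 3-methoxyphenyl at this position would be the direct test, with a 4-aminophenyl as a further probe of the same place. From the compounds shown here alone, it also remains open whether the same replacement would lift the low number of compound 3, which carries the 2,5-dimethylphenyl, or would change the high number of compound 2, which carries the 2,3-dimethylphenyl.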